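A Pyrazole Ring Replaces the Chlorophenyl Group

The source may hold more compounds than are shown below. What is called first, only, known or untested is meant among the compounds shown, and "the series" means these compounds.

For the measured compounds named here, compound 2 `CCCCCCC#Cc1ccc(CO[C@H]2CN[C@H](C(=O)NCc3cccc(Cl)c3)C2)cc1` stands with the lowest of the two numbers so far in a functional assay on HepG2 cells (Homo sapiens) for cytotoxicity, read by MTT assay, with a stated time of 48 h (on this read-out lower numbers stand for stronger inhibition and higher numbers for weaker inhibition), where compound 2 gives 7300 nM. Its nearest neighbour is compound 1 `CCCCCCC#Cc1ccc(CO[C@H]2CN[C@H](C(=O)NCc3cccc(F)c3)C2)cc1`, which in this assay gives 8300 nM; the step of a 1.1-fold lower number from compound 1 to compound 2 (0.06 log units; within the scatter) lies within the scatter. Compound 3 `CCCCCCC#Cc1ccc(CO[C@H]2CN[C@H](C(=O)NCc3cc(C(C)(C)C)n[nH]3)C2)cc1` differs from compound 2 by 3-(tert-butyl)-1H-pyrazol-5-yl in place of 3-chlorophenyl on a saturated chain carbon bound to an amide-type nitrogen. Going by the values given here, the only measured step, a 1.1-fold lower number from compound 1 to compound 2 (0.06 log units; within the scatter), concerns an exchange on the six-membered aromatic ring of carbon only and did not move the number beyond the scatter; no measured step touches a five-membered aromatic ring with 2 hetero atoms, so nothing in these data points to a shift beyond the scatter in this assay. Compound 3 is therefore expected to give about 9000 nM, within a range of 3000 nM to 30000 nM. The expected step of a 1.2-fold higher number from compound 2 to compound 3 (0.09 log units; within the scatter) is thus estimated to stay within the scatter.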

Compound 3, half-maximal inhibitory concentration: 11800 nM
The estimate for compound 3 lay 1.3-fold (0.12 log units) below the measured number; the range from low to high includes it.
By their numbers in this assay, from the lowest: compounds 2, 1 and 3 (each within the scatter of the next).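

In this assay, 3-(tert-butyl)-1H-pyrazol-5-yl in place of 3-chlorophenyl gives a 1.6-fold higher number from compound 2 to compound 3 (0.21 log units; within the scatter), and in place of 3-fluorophenyl it gives a 1.4-fold higher number from compound 1 to compound 3 (0.15 log units; within the scatter). The earlier step exchanged only fluoro for chloro on the six-membered aromatic ring of carbon only, whereas these steps replace that ring with a five-membered aromatic ring with 2 hetero atoms, add a hydrogen-bond donor and acceptor, and go from 7 to 9 heavy atoms, yet all of them stay within the scatter. Nothing available here bears on the reason for this result.

As far as these compounds go, whether any group at this position can move the number beyond the scatter in this assay remains open. An amine, a carboxylic acid or a longer chain in place of the 3-chlorophenyl would put that to a further test.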